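Ester to Hexyl Ether at the Same Position

The source may report more compounds than this note shows. Statements on the series, on what has been measured and on what is new or still open speak of the compounds shown alone.

Within the data shown here, compound 2 `CN(C)CCCC(=O)OCc1c(F)c(N)c2c(=O)cc(-c3ccc(N)c(F)c3)oc2c1F` is the only compound here with a plain number in a functional assay on MCF7 cells (Homo sapiens) for cytotoxicity, read by neutral red uptake, with a stated time of 3 days; on this read-out higher numbers stand for weaker inhibition and lower numbers for stronger inhibition: compound 2 gives 29 nM. Compound 1 `Nc1ccc(-c2cc(=O)c3c(N)c(F)c(C(=O)O)c(F)c3o2)cc1F`, which carries a carboxy group on the shared core where compound 2 carries the ester, reaches only a limit of the assay, and in this assay compound 1 gives > 10000 nM. Among the measured compounds shown here, the single measured step, an at least 340-fold lower number from compound 1 to compound 2 (2.53 log units; beyond the scatter), rests on the limit of > 10000 nM in this assay, at which 1 of the 2 values shown sits, and so sets only a floor for its size rather than a measured magnitude.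

Compound 3 `CCCCCCOCc1c(F)c(N)c2c(=O)cc(-c3ccc(N)c(F)c3)oc2c1F` keeps the core of compound 2 and alters the side chain: hexyl in place of (3-(dimethylamino)propyl)carbonyl on an oxygen on a saturated carbon. For the measured compounds named here, no measured step covers an exchange of this kind; the step from compound 1 to compound 2 concerns carboxy against the ester and says nothing about the ester against an ether. In this assay compound 3 is therefore expected to give about 60 nM, with a plausible range from 10 nM to 400 nM. That estimate means a 2.1-fold higher number from compound 2 to compound 3 (0.32 log units; beyond the scatter), a step expected to stay near the scatter, with the wide range reflecting the absence of any comparable measured change.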

Compound 3, half-maximal inhibitory concentration: 7100 nM
Compound 3: the middle estimate sits 120-fold (2.07 log units) below what was measured; measured number above the stated range.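

The side chain on this oxygen decides much of the outcome: in this assay, hexyl in place of (3-(dimethylamino)propyl)carbonyl gives a 240-fold higher number from compound 2 to compound 3 (2.39 log units; beyond the scatter). Compound 1 alone could suggest that losing the carboxy group was enough for a low number, but compound 3 also lacks that group and still loses most of the strength seen with compound 2, so the low number does not come with just any chain at this position. Against the carboxy compound, the (hexyloxy)methyl exchange gives an at least 1.4-fold lower number from compound 1 to compound 3 (0.14 log units; that floor lies within the scatter), so this floor does not establish a real difference between the two, and the comparison ends at a limit of the assay: the limit of > 10000 nM in this assay, at which 1 of the 3 values shown sits.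

The exchange from compound 2 to compound 3 removes the dimethylamino nitrogen and the carbonyl together, so the compounds shown cannot tell which of them matters, or whether both do. A plain hexanoyl ester, which keeps the carbonyl without the amine, and an ether chain ending in a dimethylamino group, which keeps the amine without the carbonyl, would pull the two apart.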